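From 1,3-thiazol-2-yl to 5-carboxypyridin-2-yl on the amide-type nitrogen

A few compounds are considered here, and "the series" means these few. Any claim that something is new, unique, unknown or untested is made for them only; others in the source may bear on it.

In a physicochemical assay for solubility (on this read-out higher numbers stand for higher solubility and lower numbers for lower solubility), compound 2 `COC[C@H](C)Oc1cc(Oc2cc(F)cc(F)c2)cc(C(=O)Nc2nccs2)c1` reports only a limit, < 700 nM, and not an exact number. Compound 3 `COC[C@H](C)Oc1cc(Oc2cc(F)cc(F)c2)cc(C(=O)Nc2ccc(C(=O)O)cn2)c1` differs from it in one place: 5-carboxypyridin-2-yl in place of 1,3-thiazol-2-yl on an amide-type nitrogen. In words, 5-carboxypyridin-2-yl stands in place of 1,3-thiazol-2-yl on an amide-type nitrogen. Among the compounds with values here, no measured pair of compounds isolates this change, so the only guide is compound 1 `COC[C@H](C)Oc1cc(Oc2ccc(S(C)(=O)=O)cc2)cc(C(=O)Nc2ccc(C(=O)O)cn2)c1`, which also carries 5-carboxypyridin-2-yl. In this assay, compound 1 also reports only a limit, > 3000000 nM. Resting on that limit of compound 1, a large upward step in this assay is expected, well beyond the usual scatter. The estimated change is an at least 1400-fold higher number from compound 2 to compound 3 (3.15 log units; beyond the scatter). Compound 3 is expected to read about 1000000 nM, with an estimated range from 150000 nM to 3000000 nM.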

Compound 3, solubility: 805000 nM
Compound 3: middle estimate off by 1.2-fold (0.09 log units), on the high side; the measured number falls inside the stated range.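

In this assay, putting 5-carboxypyridin-2-yl in place of 1,3-thiazol-2-yl on the amide-type nitrogen gives an at least 1100-fold higher number from compound 2 to compound 3 (3.06 log units; beyond the scatter), and this pair now isolates that single change. The true step could be larger, because compound 2 gives only a limit: the limit of < 700 nM in this assay, at which 1 of the 3 values shown sits.

With 5-carboxypyridin-2-yl kept, putting 3,5-difluorophenyl in place of 4-(methylsulfonyl)phenyl on an oxygen on an aromatic ring gives an at least 3.7-fold lower number from compound 1 to compound 3 (0.57 log units; beyond the scatter), so the group at this second place also moves the number, and this step too is only a minimum, because compound 1 gives only a limit: the limit of > 3000000 nM in this assay, at which 1 of the 3 values shown sits.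

The compounds shown leave open whether the carboxylic acid or the pyridine ring accounts for the rise; a plain pyridin-2-yl or a methyl ester would help separate the two. As far as these compounds go, the exact size of both steps also stays open while each rests on a limit.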